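Permeability notes on the aryl-ether series

The compounds below may be only part of what the source reports. "The series", "measured", "known", "first", "only" and "open" are said of these compounds alone.

compound 1 `COc1ccc(-c2ccc3c(NCCCNCc4cc(F)ccc4OC)ccnc3c2)cc1`: 237 10^-6 cm/s
compound 2 `COc1ccc(F)cc1CNCCCNc1ccnc2cc(Cc3ccc(F)cc3)ccc12`: 23 10^-6 cm/s
compound 3 `COc1ccc(F)cc1CNCCCNc1ccnc2cc(Oc3ccc(Cl)cc3)ccc12`: 317 10^-6 cm/s

All values come from an ADME assay for permeability, using PAMPA, with a stated time of 30 min, at pH 7.4; on this read-out lower numbers stand for lower permeability and higher numbers for higher permeability. Compound 3 carries the highest number of the three, but compound 1 sits within the scatter of it, as a 1.3-fold higher number from compound 1 to compound 3 (0.13 log units; within the scatter) shows; only compound 2 lies clearly apart, see a 14-fold higher number from compound 2 to compound 3 (1.14 log units; beyond the scatter) and a 10-fold lower number from compound 1 to compound 2 (1.01 log units; beyond the scatter). Compound 4 `COc1ccc(F)cc1CNCCCNc1ccnc2cc(Oc3ccccc3OC)ccc12` differs from compound 3 by 2-methoxyphenyl in place of 4-chlorophenyl on an oxygen on an aromatic ring. Within the data shown here, no measured step changes the substituent on the phenoxy ring itself; the steps that bear on this position only swap the whole group, and keeping the ether link gave a step within the scatter. The oxygen link of compound 3 is retained in compound 4, so the step of a 1.3-fold lower number from compound 3 to compound 4 (0.12 log units; within the scatter) is expected to stay within the scatter. Compound 4 is estimated at 240 10^-6 cm/s, range 110 10^-6 cm/s to 450 10^-6 cm/s.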

Compound 4, apparent permeability: 317 10^-6 cm/s
The estimate for compound 4 lay 1.3-fold (0.12 log units) below the measured number; low and high end bracket the measured number.
By their numbers in this assay, from the lowest: compound 2; then compounds 1, 3 and 4 (each within the scatter of the next).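

Among these compounds, compound 4 shows that the aryl group on the ether oxygen can change from 4-chlorophenyl to 2-methoxyphenyl while the number holds in this assay (no change at the digits printed from compound 3 to compound 4 (within the scatter)); the earlier steps only swapped the whole group. The gap to the 4-fluorobenzyl compound persists (a 14-fold higher number from compound 2 to compound 4 (1.14 log units; beyond the scatter)), and the directly attached 4-methoxyphenyl stays close (a 1.3-fold higher number from compound 1 to compound 4 (0.13 log units; within the scatter)). No supporting data bear on why these steps fall as they do.

As far as these compounds go, whether the oxygen link or the ring substituent sets the gap to compound 2 stays open, since both differ in those steps. From the compounds shown here alone, how a carboxylic acid or an amine on the phenoxy ring would read is also open.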